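The source may report more compounds than this note shows. Statements on the series, on what has been measured and on what is new or still open speak of the compounds shown alone.

Notes on the thiourea and urea chalcone pair.

Compound 1 `O=C(/C=C/c1ccc(Cl)c(Cl)c1)c1ccc(NC(=S)Nc2ccc(Cl)cc2)cc1` and compound 2 `O=C(/C=C/c1ccc(Cl)cc1)c1ccc(NC(=S)Nc2ccc(Cl)cc2)cc1` share a thiourea-linked core and differ in one place, (hydrogen in place of chloro on an aromatic carbon). In a functional assay on the whole organism (Abdomen, strain Swiss) for inhibition, with Mus musculus as the target, with a stated time of 30 min, at a dose of 10 mg/kg by the intraperitoneal route (on this read-out lower numbers stand for less inhibition and higher numbers for more inhibition at the one dose given (going by the name of the read-out)), compound 1 gives 97.5%. In this assay compound 2 gives 100%. The step between them is a number 2.5 percentage points higher from compound 1 to compound 2 (within the scatter), so the two numbers cannot be told apart.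

Compound 3 `O=C(Nc1ccc(Cl)cc1)Nc1ccc(C(=O)/C=C/c2ccc(Cl)c(Cl)c2)cc1` carries a urea in place of the thiourea; the difference between its core and the core of compound 1 is not broken down here. In this assay compound 3 gives 21.6%, the lowest of the three numbers, beyond the scatter from compound 1 and from compound 2.

Compound 4 `O=C(Nc1ccc(Cl)cc1)Nc1ccc(C(=O)/C=C/c2ccc(Cl)cc2)cc1` is not yet measured. It stands to compound 3 as compound 2 stands to compound 1: the change is hydrogen in place of chloro on an aromatic carbon, the same change at the same place on the same kind of ring.

The step expected here is a number 3.4 percentage points higher from compound 3 to compound 4 (within the scatter), which rests on a number 2.5 percentage points higher from compound 1 to compound 2 (within the scatter) having stayed within the scatter on the thiourea core; there is no sign from the measured compounds that the loss of this chloro group moves the read-out much. The low standing of compound 3 is therefore expected to carry over, and compound 4 is estimated at 25%. Within the data shown here, for compound 4 the expected range runs from 5% to 50%, the width reflecting that only one earlier instance of this change is available.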

Compound 4, a percentage reported as inhibition, in the whole organism at one dose (the size of the read-out at that dose, not a potency): 51%
Compound 4: middle estimate off by 26 percentage points, on the low side; the whole stated range lies below it.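

In this assay the change from 3,4-dichlorophenyl to 4-chlorophenyl does not carry over in size from the thiourea core to the urea core: the same change on two cores in this assay, a number 2.5 percentage points higher (within the scatter) from compound 1 to compound 2 and a number 29.4 percentage points higher (beyond the scatter) from compound 3 to compound 4, 26.9 percentage points apart, beyond the scatter of two such steps. On the urea core the change gives a number 29.4 percentage points higher from compound 3 to compound 4 (beyond the scatter), whereas on the thiourea core the same change could not be told from the scatter, so in this series a step read on one of these cores is a poor guide to its size on the other. Among these compounds, this rests on only two pairs at one dose, and it does not show why the two cores differ, nor whether the flat step on the thiourea core reflects the read-out being close to its top, since compound 1 gives 97.5% and compound 2 gives 100%.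

The compounds shown leave open how the same change behaves on a third linking group, such as a simple amide or a longer chain in place of the urea or thiourea. They also leave open what a methoxy group or an amine would do in place of this chloro group on either core, and whether the gap between the two steps would hold at a lower dose.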